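Swapping Trifluoromethyl for Methyl in Compound 3

This account rests on a few compounds, and the source may have more. Where it says the series, first, only, none or still open, it means among the compounds named here.

In a functional assay on U-373MG ATCC cells (Homo sapiens) for inhibition, read by MTT assay, with a stated time of 72 h (a lower number here means a stronger inhibitor, a higher number a weaker inhibitor), compound 1 `O=C(NNC(=O)C1CC1c1ccc(OCC(F)(F)F)cc1)c1ccncc1` gives 19000 nM, the higher of the two numbers recorded, while compound 2 `CC(C)=CCC/C(C)=C/COc1ccc(C2CC2C(=O)NNc2nncc3ccccc23)cc1` gives 9000 nM. Compound 3 `CCOc1ccc(C2CC2C(=O)NNC(=O)c2ccncc2)cc1` differs from compound 1 at a single place: methyl in place of trifluoromethyl on a saturated chain carbon bound to an oxygen on an aromatic ring. Within the data shown here, no measured pair shows this change, so nothing anchors its size. Both recorded values sit at weak inhibition, and the estimate for compound 3 keeps it in that region; the estimated step of a 1.1-fold higher number from compound 1 to compound 3 (0.02 log units; within the scatter) is expected to stay within the scatter. Compound 3 is therefore expected to give about 20000 nM, in a range from 8000 nM to 50000 nM.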

Compound 3, half-maximal inhibitory concentration: 63000 nM
For compound 3 the middle estimate is 3.2-fold (0.50 log units) below the measured one; the measured number lies above the stated range.
By their numbers in this assay, from the lowest: compound 2; then compound 1; then compound 3.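

In this assay, methyl in place of trifluoromethyl on a saturated chain carbon bound to an oxygen on an aromatic ring gives a 3.3-fold higher number from compound 1 to compound 3 (0.52 log units; beyond the scatter). This position therefore responds to the change, and of this pair, compound 1 is the stronger inhibitor. Nothing available here accounts for the size or direction of this step.

Among these compounds, with only this pair, it remains open whether a longer chain such as propyl, or a terminal hydroxyl group, would read closer to compound 1 or compound 3. On these data alone, whether the same step would hold on a different core also remains open.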